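The source may report more compounds than this note shows. Statements on the series, on what has been measured and on what is new or still open speak of the compounds shown alone.

Measured so far:

Compound 1, `COc1ccccc1/C=C(/Sc1ccc(C)cc1)C(=O)c1ccc(Cl)cc1`, gives 25000 nM in a functional assay on DU-145 cells (Homo sapiens) for inhibition, read by trypan blue exclusion, with a stated time of 96 h; on this read-out higher numbers stand for weaker inhibition of growth and lower numbers for stronger inhibition of growth.
Compound 2, `Cc1cc(C)cc(/C=C(/Sc2ccc(Br)cc2)C(=O)c2ccc(Cl)cc2)c1`, gives 10000 nM in this assay.

Of the two numbers shown, compound 2 stands lowest, and its nearest neighbour, compound 1, is beyond the usual scatter of repeated measurements, so compound 2 inhibits growth more strongly than compound 1 on these numbers. Among the measured compounds shown here, no pair of measured compounds differs in only one place, so no measured step is available to anchor a prediction.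

The next compound, compound 3, `COc1ccccc1/C=C(/Sc1ccc(Br)cc1)C(=O)c1ccc(Cl)cc1`, is yet to be measured in this assay. Compound 3 differs from compound 2 as follows: 2-methoxyphenyl in place of 3,5-dimethylphenyl on a double-bonded chain carbon bound to a double-bonded chain carbon.

For the measured compounds named here, with only two measured compounds, and no single-place step between them, the expectation for compound 3 rests on the observation that the compound carrying the 2-methoxyphenyl group, compound 1, gave the weaker number, 25000 nM. The step from compound 2 to compound 3 is therefore expected to go upward, toward weaker inhibition, by roughly a 2.0-fold higher number from compound 2 to compound 3 (0.30 log units; within the scatter), which is slightly beyond the scatter. Compound 3 is estimated at 20000 nM, with a plausible range of 8000 nM to 50000 nM.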

Compound 3, concentration for 50% growth inhibition: 10000 nM
Beside the measured number, compound 3's estimate is 2.0-fold (0.30 log units) above it; low and high end bracket the measured number.
By their numbers in this assay, from the lowest: compounds 2 and 3 (each within the scatter of the next); then compound 1.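

In this assay, 2-methoxyphenyl in place of 3,5-dimethylphenyl on a double-bonded chain carbon bound to a double-bonded chain carbon gives no change at the digits printed from compound 2 to compound 3 (within the scatter), so these two groups cannot be told apart at this position, even though only 2-methoxyphenyl carries a hydrogen-bond acceptor. Bromo in place of methyl on an aromatic carbon gives a 2.5-fold lower number from compound 1 to compound 3 (0.40 log units; beyond the scatter), a modest step showing that 2-methoxyphenyl does not by itself bring the weaker number of compound 1, since compound 3 carries the same group. Nothing available here explains either result.

Still open, going by these compounds, is whether this position would accept groups of a different kind, such as an amine or a carboxylic acid, or whether a change of that sort would separate the compounds where these two groups do not. On these data alone, it also remains unknown whether bromo in place of methyl would give a similar step with 3,5-dimethylphenyl on the chain, because so far that change can be read only with 2-methoxyphenyl.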